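A few compounds are considered here, and "the series" means these few. Any claim that something is new, unique, unknown or untested is made for them only; others in the source may bear on it.

In a functional assay on A549 cells (Homo sapiens) for antiproliferative activity, read by spectrophotometry, with a stated time of 2 days; on this read-out higher numbers stand for weaker inhibition of growth and lower numbers for stronger inhibition of growth:
- compound 1 `COc1ccc(Nc2ncc(C(F)(F)F)c(N3Cc4cccc(N(C)S(C)(=O)=O)c4C3)n2)cc1C(F)(F)F`: > 30000 nM, a limit of the assay
- compound 2 `CC(=O)N1CCN(c2ccc(Nc3ncc(C(F)(F)F)c(N4Cc5cccc(N(C)S(C)(=O)=O)c5C4)n3)cc2)CC1`: 1300 nM
- compound 3 `COc1cc(Nc2ncc(C(F)(F)F)c(N3Cc4cccc(N(C)S(C)(=O)=O)c4C3)n2)cc(OC)c1`: 24800 nM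

Among the actual numbers, compound 3 stands higher at 24800 nM, and compound 2 reads lower at 1300 nM. Compound 4 `CN(c1cccc2c1CN(c1nc(Nc3cc(Cl)cc(C(F)(F)F)c3)ncc1C(F)(F)F)C2)S(C)(=O)=O` carries 3-chloro-5-(trifluoromethyl)phenyl in place of 3,5-dimethoxyphenyl on a nitrogen on an aromatic ring.

Going by the values given here, the only measured step at this place, an at least 1.2-fold lower number from compound 1 to compound 3 (0.08 log units; that floor lies within the scatter), stays within the scatter. Compound 1 supplies its starting point, (the limit of > 30000 nM in this assay, at which 1 of the 3 values shown sits). No change beyond the scatter is therefore expected in this assay, in either direction. The expected step is a 1.2-fold lower number from compound 3 to compound 4 (0.09 log units; within the scatter). Compound 4 is estimated at 20000 nM, with an expected range of 6000 nM to 40000 nM.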

Compound 4, concentration for 50% growth inhibition: 6700 nM
Compound 4: the middle estimate sits 3.0-fold (0.47 log units) above what was measured; measured number inside the range.
By their numbers in this assay, from the lowest: compound 2; then compound 4; then compound 3. At a limit, above all of these: compound 1.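

In this assay this place, on a nitrogen on an aromatic ring, now shows a change beyond the scatter: 3-chloro-5-(trifluoromethyl)phenyl in place of 3,5-dimethoxyphenyl gives a 3.7-fold lower number from compound 3 to compound 4 (0.57 log units; beyond the scatter). The same group in place of 4-methoxy-3-(trifluoromethyl)phenyl gives an at least 4.4-fold lower number from compound 1 to compound 4 (0.65 log units; beyond the scatter). The reading for compound 1 is a limit, so that step has only a floor: the limit of > 30000 nM in this assay, at which 1 of the 4 values shown sits.

The compounds shown leave open whether the chlorine or the trifluoromethyl carries the step to compound 4. On these data alone, how an amine or a carboxylic acid on this phenyl ring would read also stays open.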